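The source may hold more compounds than are shown below. What is called first, only, known or untested is meant among the compounds shown, and "the series" means these compounds.

Going by the values given here, the two compounds measured so far share one core and differ only in the methoxy pattern on one aromatic ring. Compound 2 `COc1cc(-c2cc(/C=C/C(=O)c3ccc(N)cc3)[nH]n2)cc(OC)c1OC` gives 7260 nM in a functional assay on OVCAR-3 cells (Homo sapiens) for inhibition, read by sulforhodamine B assay, with a stated time of 48 h; on this read-out higher numbers stand for lower toxicity in this test and lower numbers for higher toxicity in this test. Compound 1 `COc1ccc(-c2cc(/C=C/C(=O)c3ccc(N)cc3)[nH]n2)cc1` gives 7090 nM in this assay. Compound 2 holds the highest of the two numbers, and its nearest neighbour is compound 1, whose value sits within the scatter of it, so the two values show no separation that can be trusted. Compound 3 `COc1ccc(-c2cc(/C=C/C(=O)c3ccc(N)cc3)[nH]n2)cc1OC` differs from compound 2 in one place: hydrogen in place of methoxy on an aromatic carbon. Among the compounds with values here, no step between two measured compounds matches this change, so any expectation rests on compounds 1 and 2 alone, whose values in this assay lie within the scatter of each other even though one carries a single methoxy group and the other three. Removing one methoxy group from compound 2 is therefore expected to give a step of a 1.0-fold lower number from compound 2 to compound 3 (0.02 log units; within the scatter), that is, none beyond the scatter. Compound 3 is estimated to give 7000 nM in this assay, with a range from 3500 nM to 14000 nM.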

Compound 3, concentration lethal to 50% of the cells: 9140 nM
The estimate for compound 3 lay 1.3-fold (0.12 log units) below the measured number; the measured number falls inside the stated range.
By their numbers in this assay, from the lowest: compounds 1, 2 and 3 (each within the scatter of the next).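

Compound 1 and compound 2 differ in more than one place, so neither could show what a single methoxy group on this ring does; compound 3 now links to each of them through one change. In (this assay), hydrogen in place of the methoxy group on the aromatic carbon ortho to a methoxy group and meta to a large group gives a step (a 1.3-fold higher number from compound 2 to compound 3 (0.10 log units; within the scatter)), and methoxy in place of hydrogen, starting from the other side, gives a step (a 1.3-fold higher number from compound 1 to compound 3 (0.11 log units; within the scatter)), so this exchange, read in both of these single steps, moves the number by no more than the scatter. Nothing measured here on the compounds themselves speaks to why these numbers lie so close together.

What the compounds shown leave open is whether a different group on this aromatic carbon, such as an amine or a carboxylic acid, or a longer chain such as ethoxy in place of methoxy, would give a step beyond the scatter. On these data alone, it also remains open whether the same holds for the methoxy group that all three compounds share, were hydrogen to replace it.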